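Fluorophenyl placement and tolerated concentration on a shared core

The source may report more compounds than this note shows. Statements on the series, on what has been measured and on what is new or still open speak of the compounds shown alone.

Measured so far:
compound 1, `COc1ccccc1Oc1c(N)nc(-c2ccccc2F)nc1Cl`: > 80000 nM
compound 2, `COc1ccccc1Oc1c(N)nc(-c2ccc(F)cc2)nc1Cl`: 42600 nM
compound 3, `COc1ccccc1Oc1c(N)nc(-c2ccccc2F)nc1OCCO`: 39500 nM

In a toxicity assay on HaCaT cells (Homo sapiens) for cytotoxicity, read by CCK-8 assay, with a stated time of 24 h (a higher number here means that more compound is tolerated, a lower number that less compound is tolerated), compound 1 reaches only a limit, namely (the limit of > 80000 nM in this assay, at which 1 of the 3 values shown sits). From compound 1 to compound 2 the change is 4-fluorophenyl in place of 2-fluorophenyl on an aromatic carbon, and this assay shows an at least 1.8-fold lower number from compound 1 to compound 2 (0.27 log units; that floor lies within the scatter). From compound 1 to compound 3 the change is 2-hydroxyethoxy in place of chloro on an aromatic carbon, with an at least 2.0-fold lower number from compound 1 to compound 3 (0.30 log units; that floor lies within the scatter). The values of compound 2 and compound 3 lie within the scatter of each other.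

Compound 4, `COc1ccccc1Oc1c(N)nc(-c2ccc(F)cc2)nc1OCCO`, is not yet measured. It differs from compound 3 by 4-fluorophenyl in place of 2-fluorophenyl on an aromatic carbon. This is the same kind of change as that from compound 1 to compound 2, but the surroundings differ: there the place was meta to a chloro group and para to a group of 9 heavy atoms, here it is meta to a 2-hydroxyethoxy group and para to a 2-methoxyphenoxy group. The two cores differ by 2-hydroxyethoxy in place of chloro on an aromatic carbon.

Since the earlier step of this kind gave only a floor within the scatter, a small step is expected here, a 1.3-fold lower number from compound 3 to compound 4 (0.12 log units; within the scatter). Compound 4 is expected to give about 30000 nM, between 12000 nM and 70000 nM.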

Compound 4, half-maximal cytotoxic concentration: 15100 nM
The estimate for compound 4 lay 2.0-fold (0.30 log units) above the measured number; measured number inside the range.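

In this assay, on the core carrying 2-hydroxyethoxy, 4-fluorophenyl in place of 2-fluorophenyl gives a 2.6-fold lower number from compound 3 to compound 4 (0.42 log units; beyond the scatter), and on the core carrying 4-fluorophenyl, 2-hydroxyethoxy in place of chloro gives a 2.8-fold lower number from compound 2 to compound 4 (0.45 log units; beyond the scatter). Both steps lie beyond the scatter, so each change has a readable effect on one core, but the comparison with the core of compound 1 rests on a limit and shows no transfer of step size, nor any difference between cores, for the fluorophenyl change: the same change on two cores in this assay, an at least 1.8-fold lower number (0.27 log units; that floor lies within the scatter) from compound 1 to compound 2 and a 2.6-fold lower number (0.42 log units; beyond the scatter) from compound 3 to compound 4; the limit leaves it open whether they differ. The same restriction applies to the exchange of chloro for 2-hydroxyethoxy: the same change on two cores in this assay, an at least 2.0-fold lower number (0.30 log units; that floor lies within the scatter) from compound 1 to compound 3 and a 2.8-fold lower number (0.45 log units; beyond the scatter) from compound 2 to compound 4; the limit leaves it open whether they differ.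

The compounds shown leave open whether a plain phenyl group would fall in line with either fluorophenyl group on these two cores. They also leave open whether the step seen with 2-hydroxyethoxy would hold for a longer chain, an amine or a carboxylic acid in the same place.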